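Cytotoxicity of two amide analogs and a fluoro variant

The source may report more compounds than this note shows. Statements on the series, on what has been measured and on what is new or still open speak of the compounds shown alone.

Measured so far in an ADME assay on THP-1 cells (Homo sapiens) for cytotoxicity, read by WST assay, with a stated time of 24 h; on this read-out higher numbers stand for weaker inhibition and lower numbers for stronger inhibition:
- compound 1 `COc1ccccc1NC(=O)c1ccc2cccc(O)c2n1`: > 30000 nM, a limit of the assay, not a number
- compound 2 `COc1cccc(NC(=O)c2ccc3cccc(O)c3n2)c1`: > 30000 nM, likewise a limit

Compound 1 thus stands at the ceiling of the measurement in this assay; nothing more than a limit is known for it. Among the compounds with values here, the one other value is a limit as well, so the series gives the limit of > 30000 nM in this assay, at which 2 of the 2 values shown sit, and no numbered value to compare against. Within the data shown here, no step between measured compounds is available, and where the methoxy sits on the outer ring (one position in compound 1, another in compound 2) makes no visible difference at this ceiling.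

Compound 3 `O=C(Nc1ccccc1F)c1ccc2cccc(O)c2n1` carries fluoro in place of methoxy on an aromatic carbon. With both measured compounds at the limit, there is no ground to expect a step beyond the scatter, in either direction; the expected step from compound 1 to compound 3 is a step that the limit leaves unreadable from compound 1 to compound 3 in this assay, which is to say none that the assay would resolve. Compound 3 is expected to give 40000 nM in this assay, within 15000 nM to 120000 nM, and most probably to be reported again only as a limit.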

Compound 3, half-maximal inhibitory concentration: > 30000 nM
Compound 3: a limit, no number; the forecaster's own chance of this, stated with the estimate: 85%; the middle value is on the limit's open side.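

Compound 1 and compound 3 both stand only as limits in this assay, so no step can be read for fluoro in place of methoxy on an aromatic carbon, and the series holds a single shared value: the limit of > 30000 nM in this assay, at which 3 of the 3 values shown sit.

The compounds shown leave open what number any of the three would give in this assay, and whether any change to the shared core would bring a value within reach of the assay.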